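The compounds below may be only part of what the source reports. "The series", "measured", "known", "first", "only" and "open" are said of these compounds alone.

Measured so far in this series:
compound 1 `CC[C@H]1O[C@H](COCc2ccccc2)[C@@H](OCc2ccccc2)[C@H](OCc2ccccc2)[C@H]1O` — > 50000 nM
compound 2 `CCC[C@H]1O[C@H](COCc2ccccc2)[C@@H](OCc2ccccc2)[C@H](OCc2ccccc2)[C@H]1O` — 23600 nM
compound 3 `C[C@@H]1O[C@H](COCc2ccccc2)[C@@H](OCc2ccccc2)[C@H](OCc2ccccc2)C1=O` — > 50000 nM

All three were run in a functional assay on HOS cells (Homo sapiens) for antiproliferative activity, read by sulforhodamine B assay; on this read-out higher numbers stand for weaker inhibition of growth and lower numbers for stronger inhibition of growth. For compound 1 the value is only an assay limit, > 50000 nM. Compound 2 gives 23600 nM. For compound 3 the value is again an assay limit, > 50000 nM. The change from compound 1 to compound 2 is methyl in place of hydrogen on a saturated chain carbon, two bonds along the chain from a saturated ring carbon and the step is an at least 2.1-fold lower number from compound 1 to compound 2 (0.32 log units; beyond the scatter), starting from the limit noted in the limit of > 50000 nM in this assay, at which 2 of the 3 values shown sit.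

Compound 4 `CC[C@@H]1O[C@H](COCc2ccccc2)[C@@H](OCc2ccccc2)[C@H](OCc2ccccc2)C1=O` is not yet measured. It differs from compound 3 by methyl in place of hydrogen on a saturated chain carbon bound to a saturated ring carbon, the same kind of change, although the place here is a saturated chain carbon bound to a saturated ring carbon rather than two bonds along the chain from one. How the core of compound 3 differs from the core of compound 1 is not broken down here.

In this assay a step of an at least 1.2-fold lower number from compound 3 to compound 4 (0.09 log units; that floor lies within the scatter) is expected, resting on an at least 2.1-fold lower number from compound 1 to compound 2 (0.32 log units; beyond the scatter). A limit is again quite possible. Compound 4 is estimated at 40000 nM.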

Compound 4, concentration for 50% growth inhibition: 4300 nM
The estimate for compound 4 lay 9.3-fold (0.97 log units) above the measured number; measured number outside the range, below it.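

In this assay, methyl in place of hydrogen on a saturated chain carbon bound to a saturated ring carbon gives an at least 11-fold lower number from compound 3 to compound 4 (1.06 log units; beyond the scatter). Set beside the earlier step, the number falls on both cores, but whether the size of the step carries over stays unsettled: the same change on two cores in this assay, an at least 2.1-fold lower number (0.32 log units; beyond the scatter) from compound 1 to compound 2 and an at least 11-fold lower number (1.06 log units; beyond the scatter) from compound 3 to compound 4; the limit leaves it open whether they differ. Both steps start from a limit and the change sits at a different place in each pair, so two pairs give no rule for other cores: the limit of > 50000 nM in this assay, at which 2 of the 4 values shown sit.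

Still open, going by these compounds, is whether a longer chain at this place lowers the number further. An amine or a carboxylic acid at this place is also untested in the compounds shown.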